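The source may report more compounds than this note shows. Statements on the series, on what has been measured and on what is new or still open speak of the compounds shown alone.

The measured compounds: compound 1 `COc1ccc(NC2=C/C(=N/NC(N)=S)C(=O)N=C2Nc2ccc(OC)cc2)cc1` with 17800 nM; compound 2 `NC(=S)N/N=C1/C=C(Nc2ccc(F)cc2)C(Nc2ccc(F)cc2)=NC1=O` with 3660 nM; compound 3 `NC(=S)N/N=C1/C=C(Nc2ccc(Br)cc2)C(Nc2ccc(Br)cc2)=NC1=O` with 5840 nM, all in a functional assay on Bel-7402 cells (Homo sapiens) for antiproliferative activity, read by MTT assay, with a stated time of 72 h; a higher number here means a weaker inhibitor, a lower number a stronger inhibitor.

Compound 2 gives the lowest of the three numbers, but the gap from compound 2 to compound 3 falls within the usual scatter, so no order between these two can be read from the data. Only compound 1 stands beyond the scatter, with a clearly higher number than compound 2.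

Compound 4 `N/C(=N\N=C1\C=C(Nc2ccc(F)cc2)C(Nc2ccc(F)cc2)=NC1=O)SCc1ccccc1` has not been measured. It differs from compound 2 by a group of 11 heavy atoms (8 carbon, 2 nitrogen, 1 sulfur; one six-membered aromatic ring of carbon only) in place of a group of 4 heavy atoms (1 carbon, 2 nitrogen, 1 sulfur; no ring), on a double-bonded nitrogen. Within the data shown here, no pair of measured compounds shows a change of this kind, so there is no measured step to lean on. The three measured compounds vary only in the substituents on the two anilines, which tells nothing about the part that changes here.

The step from compound 2 to compound 4 is therefore expected to be small, with no direction beyond the scatter claimed, a 1.4-fold higher number from compound 2 to compound 4 (0.14 log units; within the scatter). Compound 4 is estimated at 5000 nM, within a range from 1500 nM to 16000 nM.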

Compound 4, half-maximal inhibitory concentration: 7690 nM
Compound 4: middle estimate off by 1.5-fold (0.19 log units), on the low side; the range from low to high includes it.
By their numbers in this assay, from the lowest: compounds 2, 3 and 4 (each within the scatter of the next, the first and the last beyond it); then compound 1.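

Among these compounds, the three earlier compounds differed only on the two anilines, so compound 4 gives the first reading of a change on the double-bonded nitrogen: the group of 11 heavy atoms, with its six-membered aromatic ring of carbon only, in place of the group of 4 heavy atoms gives a 2.1-fold higher number from compound 2 to compound 4 (0.32 log units; beyond the scatter) in this assay as a modest step. The position therefore takes a much larger group with only this modest cost to the number, so the thiourea-type group of compound 2 is not shown to be required intact for activity here. Nothing measured on either group bears on why the step has this size.

On these data alone, whether a methyl group, a longer chain or a carboxylic acid in the same place would give a number nearer to that of compound 2 stays open, since this one change gives a single point. The compounds shown also leave open whether the same change would move compound 1 or compound 3 by a similar step.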